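The source may hold more compounds than are shown below. What is called first, only, known or untested is meant among the compounds shown, and "the series" means these compounds.

Measured compounds:
- compound 1 `Cn1nc2c(=O)n(CC3(O)CCN(Cc4ccc(-c5ccco5)cc4Cl)CC3)cnc2c1-c1ccc(CNCCO)cc1`: 8.2 nM
- compound 2 `Cc1ccc(-c2ccc(CN3CCC(O)(Cn4cnc5c(-c6ccc(CN)cc6)n(C)nc5c4=O)CC3)c(Cl)c2)s1`: 101 nM
- compound 3 `Cn1nc2c(=O)n(CC3(O)CCN(Cc4ccc(-c5ccsc5Cl)cc4Cl)CC3)cnc2c1-c1ccc(CN)cc1`: 453 nM

In an assay on isolated protein for inhibition of ubiquitin carboxyl-terminal hydrolase 7 (Homo sapiens), with stated times of 30 min and 2 h (a higher number here means a weaker inhibitor, a lower number a stronger inhibitor), compound 1 gives the lowest of the three numbers, and the gaps to compound 2 and to compound 3 both lie beyond the usual scatter, so on these numbers it is the strongest inhibitor of the set.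

Compound 4 `Cn1nc2c(=O)n(CC3(O)CCN(Cc4ccc(-c5ccco5)cc4Cl)CC3)cnc2c1-c1ccc(CNC2CC2)cc1` has not yet been measured. It differs from compound 1 in a single place: cyclopropyl in place of 2-hydroxyethyl on an amine nitrogen. The rest of the molecule, including the shared core and the chlorinated aryl bearing the furan, is unchanged.

Within the data shown here, no measured step bears directly on this change. Among the measured compounds shown here, the one step available, a 4.5-fold higher number from compound 2 to compound 3 (0.65 log units; beyond the scatter), concerns a different part of the molecule and tells nothing about the amine nitrogen. Compounds 2 and 3 carry a simpler amine than compound 1, but they also differ from it elsewhere, so their values cannot be read as a test of the amine substituent alone.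

For the measured compounds named here, with no direct precedent, the expectation for compound 4 is a step of a 1.5-fold higher number from compound 1 to compound 4 (0.17 log units; within the scatter) in this assay, most likely within the scatter, with a slight lean toward a higher number. The estimated value for compound 4 is 12 nM, in a range from 4 nM to 40 nM.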

Compound 4, half-maximal inhibitory concentration: 54.1 nM
Beside the measured number, compound 4's estimate is 4.5-fold (0.65 log units) below it; measured number outside the range, above it.
By their numbers in this assay, from the lowest: compound 1; then compounds 4 and 2 (each within the scatter of the next); then compound 3.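

In this assay, putting cyclopropyl in place of 2-hydroxyethyl on the amine nitrogen gives a 6.6-fold higher number from compound 1 to compound 4 (0.82 log units; beyond the scatter), so this substituent affects the strength of inhibition even though both groups contain 3 heavy atoms. Among these compounds, this is the first direct look at that position, since compounds 2 and 3 differ from compound 1 in more than the amine substituent. The swap removes the oxygen and its hydrogen-bond donor and acceptor and adds a ring all at once, and nothing measured here explains the step or shows which of these alterations matters.

An ethyl group on the same nitrogen would keep an open chain without the oxygen, so it could help separate the loss of the hydroxyl from the arrival of the ring, while 2-methoxyethyl would keep the oxygen but replace its hydrogen. Also open, going by these compounds, is how the furan-bearing compounds would compare with a plain primary amine at this position, the form carried by compounds 2 and 3.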